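Methyl in place of hydroxy hydrogen on a shared urea core

The source may report more compounds than this note shows. Statements on the series, on what has been measured and on what is new or still open speak of the compounds shown alone.

Measured compounds:
Compound 1 `O=C(Nc1cccc(-n2cc(-c3ccncc3)c(-c3cc(O)cc(Cl)c3)n2)c1)Nc1ccc(Cl)c(Cl)c1` gives -45%.
Compound 2 `COc1cc(Cl)cc(-c2nn(-c3cccc(NC(=O)Nc4ccc(Cl)c(C(F)(F)F)c4)c3)cc2-c2ccncc2)c1` gives -35%.
Compound 3 `COc1cc(Cl)cc(-c2nn(-c3cccc(NC(=O)Nc4cc(C(F)(F)F)cc(C(F)(F)F)c4)c3)cc2-c2ccncc2)c1` gives -39%.

In a functional assay on Malme-3M cells (Homo sapiens) for inhibition, read by sulforhodamine B assay, with a stated time of 48 h, tested at 100 uM (a higher number here means a weaker effect of the compound at the concentration tested, a lower number a stronger effect), compound 1 has the lowest of the three numbers, yet compound 3 and compound 2 both lie within the usual scatter of it, so the three values cannot be told apart. For the measured compounds named here, no two measured compounds differ in a single place, so no step between them is known. Compound 4 `COc1cc(Cl)cc(-c2nn(-c3cccc(NC(=O)Nc4ccc(Cl)c(Cl)c4)c3)cc2-c2ccncc2)c1` differs from compound 1 by methyl in place of hydrogen on an oxygen on an aromatic ring. With the methoxy compounds 2 and 3 sitting within the scatter of compound 1, the expected step of a number 5 percentage points higher from compound 1 to compound 4 (within the scatter) is none beyond the scatter. Compound 4 is therefore estimated at -40%, between -58% and -22%.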

Compound 4, a percentage reported as activity, at one concentration (the size of the read-out at that concentration, not a potency): -24%
The estimate for compound 4 lay 16 percentage points below the measured number; the measured number falls inside the stated range.
By their numbers in this assay, from the lowest: compounds 1, 3 and 2 (each within the scatter of the next); then compound 4.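

In this assay, the change from hydroxy to methoxy gives the first step read in one place, a number 21 percentage points higher from compound 1 to compound 4 (beyond the scatter), so this oxygen is not indifferent with this urea partner. Chloro in place of trifluoromethyl on an aromatic carbon, with the methoxy kept, gives a number 11 percentage points higher from compound 2 to compound 4 (beyond the scatter), showing that the number also moves with a change elsewhere on the shared core. No measurement at hand explains either step.

As far as these compounds go, whether the methoxy step holds with other urea partners remains open. So does the outcome of an ethoxy group or an amine at this position.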